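Replacing a Nitrile with a Methyltetrazole: Clearance Outlook

The source may hold more compounds than are shown below. What is called first, only, known or untested is meant among the compounds shown, and "the series" means these compounds.

Compound 1 `C[C@@H](Nc1nccc(Cl)c1NC(=O)CC#N)c1ccc(-c2cccc(F)c2C#N)cc1` has been measured in an in vivo ADME assay on the whole organism (strain Sprague-Dawley) for pharmacokinetics, with Rattus norvegicus as the target, at a dose of 2 mg/kg by the intravenous route (a higher number here means faster removal of the compound, a lower number slower removal), where compound 1 gives 8.3 mL/min/kg. It sits at the lower end of the two numbers shown, yet its only neighbour, compound 2 `Cc1noc(-c2c(F)cccc2-c2ccc([C@@H](C)Nc3nccc(Cl)c3NC(=O)CC#N)cc2)n1`, gives 9.5 mL/min/kg, and the gap between them is within the scatter, so no order can be read from the pair. Among the measured compounds shown here, the one measured step is a 1.1-fold higher number from compound 1 to compound 2 (0.06 log units; within the scatter). For the measured compounds named here, compound 3 `C[C@@H](Nc1nccc(Cl)c1NC(=O)CC#N)c1ccc(-c2cccc(F)c2-c2nnn(C)n2)cc1` has no measurement yet. Relative to compound 1 it carries 2-methyl-2H-tetrazol-5-yl in place of cyano on an aromatic carbon. This change resembles the step from compound 1 to compound 2 in that a cyano on an aromatic carbon is again exchanged for a methyl-bearing five-membered aromatic ring containing hetero atoms, and that step stayed within the scatter. With nothing further to draw on, compound 3 is expected to show a clearance that does not differ from that of compound 1 beyond the scatter, as a 1.1-fold higher number from compound 1 to compound 3 (0.06 log units; within the scatter) expresses. Compound 3 is therefore estimated at 9.5 mL/min/kg, with a range from 5.5 mL/min/kg to 16 mL/min/kg.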

Compound 3, clearance: 9 mL/min/kg
Beside the measured number, compound 3's estimate is 1.1-fold (0.02 log units) above it; the range from low to high includes it.
By their numbers in this assay, from the lowest: compounds 1, 3 and 2 (each within the scatter of the next).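

At the aromatic carbon ortho to a fluoro group, the exchange of cyano for 2-methyl-2H-tetrazol-5-yl gives a 1.1-fold higher number from compound 1 to compound 3 (0.04 log units; within the scatter) in this assay, so a second methyl-bearing five-membered aromatic ring, here with 4 hetero atoms, also leaves the clearance within the scatter of the nitrile. The two rings can now be set against each other directly, and a 1.1-fold lower number from compound 2 to compound 3 (0.02 log units; within the scatter) shows that the exchange of 3-methyl-1,2,4-oxadiazol-5-yl for 2-methyl-2H-tetrazol-5-yl does not separate them either, so across compounds 1, 2 and 3 the three groups at this position cannot be told apart by this read-out. Nothing available explains why the clearance stays within the scatter across groups of 2 and 6 heavy atoms.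

From the compounds shown here alone, whether this holds only for the nitrile and these methyl-bearing rings remains open, since a carboxylic acid, a primary amine or a longer alkyl chain at this position could behave differently. The three compounds also share the rest of their structure, so they leave open whether the same exchanges would stay within the scatter on a different core.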